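This account rests on a few compounds, and the source may have more. Where it says the series, first, only, none or still open, it means among the compounds named here.

Compound 3 `CN1CCN(c2ccc(Nc3ncc4nc(Nc5ccc(F)cc5)n([C@@H]5CCN(C(=O)OC(C)(C)C)C5)c4n3)cc2)CC1` holds the lowest number of the three measured compounds in a functional assay on HCC827 cells (Homo sapiens) for antiproliferative activity, read by MTT assay, with a stated time of 72 h; on this read-out higher numbers stand for weaker inhibition and lower numbers for stronger inhibition: compound 3 gives 27 nM, against compound 1 `CN1CCN(c2ccc(Nc3ncc4nc(Nc5ccc(F)cc5)n([C@@H]5CCCNC5)c4n3)cc2)CC1`, which gives 120 nM, and compound 2 `CNC(=O)CN1CC[C@H](n2c(Nc3ccc(F)cc3)nc3cnc(Nc4ccc(N5CCN(C)CC5)cc4)nc32)C1`, which gives 1520 nM. The change to compound 4 `CCOC(=O)CN1CC[C@H](n2c(Nc3ccc(F)cc3)nc3cnc(Nc4ccc(N5CCN(C)CC5)cc4)nc32)C1` is 1-((ethoxycarbonyl)methyl)pyrrolidin-3-yl in place of 1-(tert-butoxycarbonyl)pyrrolidin-3-yl on an aromatic nitrogen. Among the compounds with values here, two measured steps bear on it. Replacing the tert-butoxycarbonyl group with the (methylcarbamoyl)methyl group gave a 56-fold lower number from compound 2 to compound 3 (1.75 log units; beyond the scatter) read in reverse, a large loss; the free piperidin-3-yl group in compound 1 lies between these two, with a 4.4-fold lower number from compound 1 to compound 3 (0.65 log units; beyond the scatter) and a 13-fold higher number from compound 1 to compound 2 (1.10 log units; beyond the scatter). The (ethoxycarbonyl)methyl group of compound 4 resembles the (methylcarbamoyl)methyl group of compound 2 in being a substituted chain on the pyrrolidine nitrogen rather than a tert-butoxycarbonyl group, so a higher number than that of compound 3 is expected, though perhaps not the full loss seen with compound 2. The expected step is an 11-fold higher number from compound 3 to compound 4 (1.05 log units; beyond the scatter). Compound 4 is therefore estimated at 300 nM, within a range from 80 nM to 1200 nM.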

Compound 4, half-maximal inhibitory concentration: 1810 nM
Beside the measured number, compound 4's estimate is 6.0-fold (0.78 log units) below it; measured number above the stated range.
By their numbers in this assay, from the lowest: compound 3; then compound 1; then compounds 2 and 4 (each within the scatter of the next).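

In this assay, ethoxy in place of methylamino on a carbonyl carbon leaves the number within the scatter (a 1.2-fold higher number from compound 2 to compound 4 (0.08 log units; within the scatter)), so the high number of compound 2 does not depend on the methylamino group. The large steps (a 67-fold higher number from compound 3 to compound 4 (1.83 log units; beyond the scatter)) and (a 15-fold higher number from compound 1 to compound 4 (1.18 log units; beyond the scatter)) place compound 4 with compound 2, far from compound 3 and compound 1. Among these four compounds, then, both (carbonyl)methyl chains on the pyrrolidine nitrogen go with high numbers, whether the chain ends in the ester or in the amide, and no compound shown goes against this. The compounds shown leave open whether a carboxylic acid or a longer chain on that nitrogen would follow the same pattern. They also leave open how the unsubstituted pyrrolidin-3-yl group compares with piperidin-3-yl, since ring and substituent change together in every step from compound 1. No measurement at hand accounts for these steps.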